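A few compounds are considered here, and "the series" means these few. Any claim that something is new, unique, unknown or untested is made for them only; others in the source may bear on it.

Measured in a functional assay on the whole organism (strain Hartley) for inhibition, with Cavia porcellus as the target, with stated times of 15 min and 2 min; a higher number here means that more compound is needed for the effect, a lower number that less compound is needed:
- compound 1 `CCCCC1([C@@H](O)/C=C/C2CCC(=O)[C@@H]2CCCCCCC(=O)O)CCC1`: 0.0139 mg/kg
- compound 2 `CCCCC1([C@@H](O)/C=C/C2CCC(=O)[C@@H]2CCCCCCC(=O)OCC)CCC1`: 0.032 mg/kg
- compound 3 `CCCCC1([C@H](O)/C=C/C2CCC(=O)[C@@H]2CCCCSCC(=O)OCC)CCC1`: 0.03 mg/kg

Compound 3 sits within the scatter of compound 2 and gives a higher number than compound 1, a gap beyond the scatter.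

Compound 4 `CCCCC1([C@@H](O)/C=C/C2CCC(=O)[C@@H]2CCCCSCC(=O)OCC)CCC1` is still unmeasured. The change is the two compounds have the same atoms and bonds; at least one stereo element is drawn with a configuration in one of them and without one in the other: 1 of 4 stereo elements differ; a stereocentre at a saturated chain carbon is drawn R in compound 3 and S in compound 4: a stereocentre at a saturated chain carbon is drawn R in compound 3 and S in compound 4.

Going by the values given here, the only measured step, a 2.3-fold higher number from compound 1 to compound 2 (0.36 log units; beyond the scatter), is modest and alters no stereocentre. It gives neither size nor direction for this inversion, so the range stays wide on both sides.

The expected step in this assay is no change at the digits printed from compound 3 to compound 4 (within the scatter), and no direction is favoured. For compound 4 the estimate is 0.03 mg/kg, with an expected range of 0.006 mg/kg to 0.15 mg/kg.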

Compound 4, dose for half-maximal effect: > 0.672 mg/kg
Compound 4 was reported as a limit; the forecaster's own chance of this, stated with the estimate: 3%; middle value at least 22-fold (1.35 log units) away from the limit.
By their numbers in this assay, from the lowest: compound 1; then compounds 3 and 2 (each within the scatter of the next). At a limit, above all of these: compound 4.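

In this assay, the change at this stereocentre at a saturated chain carbon alone gives an at least 22-fold higher number from compound 3 to compound 4 (1.35 log units; beyond the scatter), the first sign that the series is sensitive to this centre, with one caution on how the pair is drawn: the fact that one of compounds 3 and 4 is drawn with a defined configuration and the other without, at the place where they differ

Compound 4 is reported only as a limit, > 0.672 mg/kg.

The steps of an at least 21-fold higher number from compound 2 to compound 4 (1.32 log units; beyond the scatter) and an at least 48-fold higher number from compound 1 to compound 4 (1.68 log units; beyond the scatter) are also large, and each includes the change to ((ethoxycarbonyl)methyl)sulfanyl.

As far as these compounds go, it remains open whether inversion at this centre has a similar effect in a chain without the sulfanyl group, or with a primary amide in place of the ethyl ester.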